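The source may hold more compounds than are shown below. What is called first, only, known or untested is meant among the compounds shown, and "the series" means these compounds.

Compound 2 `C/C=C/COc1ccc(C(CC(=O)O)c2ccccc2)cc1` and compound 1 `CCCOc1ccc(C(CC(=O)O)c2ccccc2)cc1` share one core and differ only in the chain bound through oxygen to the aromatic ring. In a functional assay on HEK293 cells for agonist activity at Free fatty acid receptor 1 (Homo sapiens), read by calcium flux (on this read-out higher numbers stand for an effect only at larger amounts of compound and lower numbers for an effect already at smaller amounts), compound 1 gives 4.8 uM, and compound 2 gives 2.71 uM, the smaller of the two numbers, though the step of a 1.8-fold lower number from compound 1 to compound 2 (0.25 log units; within the scatter) lies within the scatter, so neither compound can be called the stronger. Compound 3 `CC(C)CCOc1ccc(C(CC(=O)O)c2ccccc2)cc1` carries the next change at this place: isobutyl in place of prop-1-en-1-yl on a saturated chain carbon bound to an oxygen on an aromatic ring. Going by the values given here, only one measured step bears on it, the exchange of chains at the same position from compound 1 to compound 2, and that step stayed within the scatter. Exchanging prop-1-en-1-yl for isobutyl is therefore expected to leave the number essentially unchanged, with a step of a 1.3-fold higher number from compound 2 to compound 3 (0.11 log units; within the scatter) that does not go beyond the scatter. Compound 3 is estimated at 3.5 uM, within a range from 1.2 uM to 10 uM.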

Compound 3, concentration for half-maximal effect: 1.86 uM
Compound 3: the middle estimate sits 1.9-fold (0.27 log units) above what was measured; the range from low to high includes it.
By their numbers in this assay, from the lowest: compounds 3, 2 and 1 (each within the scatter of the next, the first and the last beyond it).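

In this assay the exchange of prop-1-en-1-yl for isobutyl gives a 1.5-fold lower number from compound 2 to compound 3 (0.16 log units; within the scatter) and so does not separate these two compounds. Going by these compounds alone, the step of a 2.6-fold lower number from compound 1 to compound 3 (0.41 log units; beyond the scatter) is the first at this position to pass beyond the scatter, though only modestly, and it shows that isopropyl in place of methyl on a saturated chain carbon, two bonds along the chain from an oxygen on an aromatic ring, can shift the number. No measured evidence accounts for this shift. The compounds shown leave open whether a longer chain such as hexyl would take the number further in the same direction. They also leave open what a chain ending in an amine or a phenyl group would do at this place.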